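Swapping tert-Butyl for Propyl on a Fused Core

The source may hold more compounds than are shown below. What is called first, only, known or untested is meant among the compounds shown, and "the series" means these compounds.

Compound 1 `CC(C)(C)n1ncc2c(Nc3ccc(OC(F)(F)F)cc3)ncnc21` gives 7300 nM in an ADME assay on BaF3 cells (Mus musculus) for cytotoxicity; on this read-out lower numbers stand for an effect already at smaller amounts and higher numbers for an effect only at larger amounts of compound.
Compound 2 `NC(=O)CCn1ccc2c(Nc3ccc(OC(F)(F)F)cc3)ncnc21` reaches only the limit > 10000 nM in this assay.
Compound 3 `CS(=O)(=O)Nc1ccc(-c2cc(Nc3ccc(OC(F)(F)F)cc3)ncn2)cc1` gives 2210 nM in this assay.

Among the two compounds with a number, compound 1 stands highest, meaning its effect appears only at larger amounts. Compound 3 sits clearly lower, by a gap beyond the usual scatter of repeated measurements. Compound 2 does not give a number at all: it sits at the limit of > 10000 nM in this assay, at which 1 of the 3 values shown sits, so only a bound is known for it.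

Compound 4 `CCCn1ncc2c(Nc3ccc(OC(F)(F)F)cc3)ncnc21` keeps the whole of compound 1 apart from one group. The change is propyl in place of tert-butyl on an aromatic nitrogen. For the measured compounds named here, no measured pair in this set shows what such a swap does in this assay, so the expectation rests on the small size of the change: both groups are short carbon chains without donors, acceptors or charge, and the place is the same. The step from compound 1 to compound 4 is therefore expected to stay within the usual scatter, as a 1.1-fold higher number from compound 1 to compound 4 (0.04 log units; within the scatter) in this assay. Compound 4 is estimated at 8000 nM, with a likely range from 3500 nM to 15000 nM, and a fair chance that only the limit is reported.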

Compound 4, half-maximal effective concentration: 6600 nM
Estimate against measurement, compound 4: 1.2-fold (0.08 log units) above, and the stated range covers the measured number.
By their numbers in this assay, from the lowest: compound 3; then compounds 4 and 1 (each within the scatter of the next). At a limit, above all of these: compound 2.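

For the compounds shown here, this is the first step in the set that changes one place only: propyl in place of tert-butyl on an aromatic nitrogen gives a 1.1-fold lower number from compound 1 to compound 4 (0.04 log units; within the scatter). Going by these compounds alone, at this position in this assay, the two carbon chains therefore cannot be told apart, something the earlier compounds could not show, since they differ from one another in more than one place. Nothing measured here explains why the two chains give such similar numbers.

The compounds shown leave open whether this tolerance extends beyond these two chains, for instance whether an amine, a carboxylic acid or a longer chain on the same nitrogen would also leave the number within the scatter of compound 1. A chain ending in an amide appears only in compound 2, which also differs in its core and is held at a limit, > 10000 nM, so it cannot answer that question.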